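Aryl substituent swap on the shared core: expected unchanged dose

The source may hold more compounds than are shown below. What is called first, only, known or untested is meant among the compounds shown, and "the series" means these compounds.

Compound 1 `O=C1NC2(CC2c2ccc3cccc(OCc4ccccc4)c3n2)C(=O)N1c1ccc(C(F)(F)F)cc1` carries a trifluoromethyl group on the phenyl ring attached to the shared core. In a functional assay on the whole organism (strain Kunming) with Mus musculus as the target, in the maximal electroshock model, with a stated time of 4 h (on this read-out higher numbers stand for an effect only at larger amounts of compound and lower numbers for an effect already at smaller amounts), compound 1 gives 300 mg/kg. Compound 2 `O=C1NC2(CC2c2ccc3cccc(OCc4ccccc4)c3n2)C(=O)N1c1ccccc1` differs from it only by hydrogen in place of trifluoromethyl on an aromatic carbon; in this assay compound 2 gives 300 mg/kg. The step of no change at the digits printed from compound 1 to compound 2 (within the scatter) shows that removing the trifluoromethyl group leaves the minimum effective dose where it was, so compound 1 stands level with compound 2 on these numbers.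

Compound 3 `COc1ccc(N2C(=O)NC3(CC3c3ccc4cccc(OCc5ccccc5)c4n3)C2=O)cc1` is the next variation at the same aromatic carbon: methoxy in place of trifluoromethyl on an aromatic carbon. Within the data shown here, the only measured step that bears on this change is no change at the digits printed from compound 1 to compound 2 (within the scatter), which is flat. Nothing in the data separates the bare phenyl from the trifluoromethyl-bearing one, so a methoxy group at the same aromatic carbon is expected to behave alike. Compound 3 is therefore expected to give 300 mg/kg in this assay, with a range from 150 mg/kg to 600 mg/kg. The expected step of no change at the digits printed from compound 1 to compound 3 (within the scatter) is no change beyond the scatter.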

Compound 3, minimum effective dose: 100 mg/kg
Compound 3: the middle estimate sits 3.0-fold (0.48 log units) above what was measured, outside the stated range (below it).
By their numbers in this assay, from the lowest: compound 3; then compounds 1 and 2 (each within the scatter of the next).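

The aromatic carbon that looked indifferent in the earlier pair does respond to what it carries. In this assay, the step of a 3.0-fold lower number from compound 1 to compound 3 (0.48 log units; beyond the scatter) and the step of a 3.0-fold lower number from compound 2 to compound 3 (0.48 log units; beyond the scatter) both go the same way, so methoxy at this carbon, on the ring's carbon para to a large group, sets compound 3 apart from both the trifluoromethyl-bearing compound and the unsubstituted phenyl, if only modestly. The flat result for the first two compounds therefore described that one pair of groups and not the position as a whole, and nothing shown here accounts for why methoxy separates from them.

From the compounds shown here alone, it remains open whether an ethoxy group, a hydroxyl group or a dimethylamino group at this aromatic carbon would follow methoxy to a lower dose or stay level with hydrogen and trifluoromethyl. Also open is whether methoxy would keep this step on another carbon of the same ring, since the three compounds shown vary only this one carbon.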